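The compounds below may be only part of what the source reports. "The series", "measured", "known", "first", "only" and "open" are said of these compounds alone.

Measured so far:
compound 1 `CN1CCC(C(=O)N2Cc3c(NC(=O)C4CCC4)n[nH]c3C2(C)C)CC1`, 140 nM
compound 2 `CC(C)(C)C(=O)N1Cc2c(NC(=O)c3ccc(F)cc3)n[nH]c2C1(C)C`, 270 nM

Compound 1 holds the lowest of the two numbers in a functional assay on A2780 cells (Homo sapiens) for antiproliferative activity, read by fluorescence, with a stated time of 72 h (a higher number here means a weaker inhibitor, a lower number a stronger inhibitor), but compound 2 lies within the scatter of it, so no order between them is claimed. Compound 3 `CN1CCC(C(=O)N2Cc3c(NC(=O)Nc4cccc(F)c4)n[nH]c3C2(C)C)CC1` differs from compound 1 in one place: (3-fluorophenyl)amino in place of cyclobutyl on a carbonyl carbon. Among the measured compounds shown here, no step between measured compounds covers this change, so its size is unknown from the series. For compound 3 the expected step is a 1.4-fold higher number from compound 1 to compound 3 (0.15 log units; within the scatter) in this assay, a shift not clearly beyond the scatter, with no firm direction. Compound 3 is therefore estimated at 200 nM, with a range from 60 nM to 700 nM.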

Compound 3, half-maximal inhibitory concentration: 350 nM
Compound 3: middle estimate off by 1.8-fold (0.24 log units), on the low side, and the stated range covers the measured number.
By their numbers in this assay, from the lowest: compounds 1, 2 and 3 (each within the scatter of the next, the first and the last beyond it).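

In this assay, among the compounds shown here, (3-fluorophenyl)amino in place of cyclobutyl on a carbonyl carbon gives a 2.5-fold higher number from compound 1 to compound 3 (0.40 log units; beyond the scatter), the only step available and one beyond the scatter. The position therefore responds to this change, but the step is modest despite the larger group with its aromatic ring and hydrogen-bond donor. No available measurement accounts for the step.

The compounds shown leave open whether the step follows the aromatic ring or the amino nitrogen. Cyclobutylamino or phenyl on the same carbonyl carbon would separate the two.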